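Trimming the Benzyl Group of Compound 2 to Ethyl

The compounds below may be only part of what the source reports. "The series", "measured", "known", "first", "only" and "open" are said of these compounds alone.

Measured compounds:
compound 1, `O=C(O)CN1C(=O)/C(=C/c2nc3ccccc3n2Cc2ccc([N+](=O)[O-])cc2)SC1=S`: 11400 nM
compound 2, `O=C(O)CN1C(=O)/C(=C/c2nc3ccccc3n2Cc2ccccc2)SC1=S`: 8760 nM
compound 3, `O=C(O)CN1C(=O)/C(=C/c2nc3ccccc3n2Cc2ccc(F)cc2F)SC1=S`: 12800 nM

In a functional assay on A549 cells (Homo sapiens) for cytotoxicity, read by MTT assay, with a stated time of 48 h (on this read-out higher numbers stand for weaker inhibition and lower numbers for stronger inhibition), compound 2 gives 8760 nM. Its neighbours sit close: a 1.3-fold lower number from compound 1 to compound 2 (0.11 log units; within the scatter) and a 1.5-fold higher number from compound 2 to compound 3 (0.16 log units; within the scatter), so all three numbers lie within the usual scatter of one another and no order among them can be read.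

Compound 4, `CCn1c(/C=C2\SC(=S)N(CC(=O)O)C2=O)nc2ccccc21`, is not yet measured. It differs from compound 2 by methyl in place of phenyl on a saturated chain carbon bound to an aromatic nitrogen. The steps that touch the same place, a 1.3-fold lower number from compound 1 to compound 2 (0.11 log units; within the scatter), a 1.1-fold higher number from compound 1 to compound 3 (0.05 log units; within the scatter) and a 1.5-fold higher number from compound 2 to compound 3 (0.16 log units; within the scatter), only swap substituents on the phenyl and all stay within the scatter; none removes the phenyl itself. With nothing pointing either way, the number for compound 4 is expected to stay near compound 2, the estimated step being a 1.3-fold higher number from compound 2 to compound 4 (0.10 log units; within the scatter). Compound 4 is therefore estimated at 11000 nM, within 5000 nM to 25000 nM.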

Compound 4, half-maximal inhibitory concentration: 9440 nM
Estimate against measurement, compound 4: 1.2-fold (0.07 log units) above; measured number inside the range.
By their numbers in this assay, from the lowest: compounds 2, 4, 1 and 3 (each within the scatter of the next).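

Unlike the earlier swaps on the phenyl, benzyl to ethyl takes the whole aromatic ring away, and in this assay the numbers still cannot be told apart: a 1.1-fold higher number from compound 2 to compound 4 (0.03 log units; within the scatter) and a 1.4-fold lower number from compound 3 to compound 4 (0.13 log units; within the scatter) and a 1.2-fold lower number from compound 1 to compound 4 (0.08 log units; within the scatter). Across these four compounds, then, a number of this size does not depend on a phenyl on this saturated chain carbon bound to an aromatic nitrogen.

Going by these compounds, whether an amine, a carboxylic acid or a longer chain at this place would give a number beyond the scatter stays open. No measurement offers an explanation for these results.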